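Adding methoxy to the anilino group of compound 3

The source may report more compounds than this note shows. Statements on the series, on what has been measured and on what is new or still open speak of the compounds shown alone.

Compound 1 `CCCOc1ccc(C(=O)Nc2cccc(C)n2)cc1` gives 11100 nM in an in vitro assay on HEK-tsA201 cells for antagonist activity at Neuronal acetylcholine receptor; alpha3/beta4 (Homo sapiens), read by fluorescence and calcium flux; a higher number here means a weaker inhibitor, a lower number a stronger inhibitor.
Compound 2 `CCCCCNc1cccc(NC(=O)c2ccc(OCCC)cc2)n1` reaches only a limit of the assay in this assay, > 100000 nM.
Compound 3 `CCCOc1ccc(C(=O)Nc2cccc(Nc3ccccc3)n2)cc1` likewise reaches only a limit in this assay, > 100000 nM.

Compound 3 thus stands at the limit, shared with one other value (the limit of > 100000 nM in this assay, at which 2 of the 3 values shown sit), and has no number of its own. Compound 4 `CCCOc1ccc(C(=O)Nc2cccc(Nc3ccc(OC)cc3)n2)cc1` differs from it by methoxy in place of hydrogen on an aromatic carbon. The measured step that bears on this part of the molecule is an at least 9.0-fold higher number from compound 1 to compound 3 (0.95 log units; beyond the scatter), where anilino in place of methyl weakened inhibition; the step that the two limits leave unreadable from compound 2 to compound 3 cannot be read. Among the measured compounds shown here, no measured step addresses a methoxy on that ring. The step expected in this assay is a number no higher from compound 3 to compound 4 (the limit leaves the size open), none beyond the scatter. Compound 4 is estimated at 100000 nM, with a range from 30000 nM to 300000 nM, most likely again only a limit.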

Compound 4, half-maximal inhibitory concentration: > 100000 nM
Compound 4: a limit, no number; the forecaster's own chance of this, stated with the estimate: 80%; the middle value sits exactly at the limit.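

Adding methoxy to the anilino ring does not restore a readable value in this assay: compound 4 gives only a limit of > 100000 nM and no number. Replacing methyl with (4-methoxyphenyl)amino gives an at least 9.0-fold higher number from compound 1 to compound 4 (0.95 log units; beyond the scatter) and so weakens inhibition, as anilino and pentylamino also do. Going by these compounds, the steps among compound 2, compound 3 and compound 4 cannot be read, so the effect of the methoxy itself stays unknown, and most values now sit at one limit: the limit of > 100000 nM in this assay, at which 3 of the 4 values shown sit.

On these data alone, whether ethyl or a plain amino group in place of methyl would keep a readable value stays open. So does whether a hydroxyl or a carboxylic acid on the anilino ring would bring a compound back from the limit.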